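Swapping a Dihydroxyphenyl for a Hydroxy-Methoxyphenyl Ester

This account rests on a few compounds, and the source may have more. Where it says the series, first, only, none or still open, it means among the compounds named here.

Going by the values given here, compound 2 `CC(/C=C/C1=CCCCC1(C)C)=C\C=C\C(C)=C\COC(=O)c1c(O)cccc1O` stands lowest of the two numbers known so far: in a functional assay on B16-F10 cells (Mus musculus) for inhibition, tested at 5 uM (on this read-out lower numbers stand for less inhibition and higher numbers for more inhibition at the one concentration tested (going by the name of the read-out)), compound 2 gives 12.7%, while compound 1 `CC(/C=C/C1=CCCCC1(C)C)=C\C=C\C(C)=C\COC(=O)c1cc(O)c(O)c(O)c1` gives 27.5%. Among the compounds with values here, the one measured step, a number 14.8 percentage points lower from compound 1 to compound 2 (beyond the scatter), came with fewer hydroxyl groups on the aromatic ring and bears directly on the next change. Compound 3 `COc1cccc(C(=O)OC/C=C(C)/C=C/C=C(C)/C=C/C2=CCCCC2(C)C)c1O` differs from compound 2 by 2-hydroxy-3-methoxyphenyl in place of 2,6-dihydroxyphenyl on a carbonyl carbon. Since losing hydroxyl groups has so far lowered the read-out, a further small decrease or none beyond the scatter is expected, a step of a number 4.7 percentage points lower from compound 2 to compound 3 (within the scatter). Compound 3 is estimated at 8%, with a range from 0% to 22%.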

Compound 3, a percentage reported as inhibition, at one concentration (the size of the read-out at that concentration, not a potency): 16.2%
For compound 3 the middle estimate is 8.2 percentage points below the measured one, within the range that was stated.
By their numbers in this assay, from the lowest: compounds 2 and 3 (each within the scatter of the next); then compound 1.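

In this assay, 2-hydroxy-3-methoxyphenyl in place of 2,6-dihydroxyphenyl on the carbonyl carbon gives a number 3.5 percentage points higher from compound 2 to compound 3 (within the scatter) and so separates these two esters by no readable amount. The methoxy-bearing ring still falls short of the 3,4,5-trihydroxyphenyl ring, with a number 11.3 percentage points lower from compound 1 to compound 3 (beyond the scatter) and a gap beyond the scatter. Going by these compounds, whether an amine or a carboxylic acid on this ring would read differently stays open. No measurement here accounts for these numbers.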